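A few compounds are considered here, and "the series" means these few. Any claim that something is new, unique, unknown or untested is made for them only; others in the source may bear on it.

In an ADME assay on a cell-free system (plasma, Rattus norvegicus) for metabolic stability, read by LC-MS, with a stated time of 60 min, tested at 100 uM (a higher number here means that more of the compound is left, a lower number that less of the compound is left), compound 1 `Cc1cc(C(=O)O)ccc1OCCCCOc1ccc(C(=O)CC(C)C)c(O)c1C` gives 100% and compound 2 `Cc1c(OCCCCOc2cccc(C(=O)O)c2)ccc(C(=O)CC(C)C)c1O` gives 100%, so compound 2 stands level with compound 1. Compound 3 `Cc1cc(OCCCCOc2ccc(C(=O)CC(C)C)c(O)c2C)ccc1C(=O)O` carries 4-carboxy-3-methylphenyl in place of 3-carboxyphenyl on an oxygen on a saturated carbon. Going by the values given here, the one measured step bearing on this exchange, no change at the digits printed from compound 1 to compound 2 (within the scatter), swaps the same kind of carboxyphenyl group at the same place. On these data alone, no change beyond the scatter is therefore expected in this assay, and the direction stays open. The expected size is a number 2 percentage points lower from compound 2 to compound 3 (within the scatter). For compound 3 the estimated value is 98%, with an expected range of 88% to 100%.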

Compound 3, percent of the compound remaining: 101%
Estimate against measurement, compound 3: 3 percentage points below; measured number above the stated range.
By their numbers in this assay, from the lowest: compounds 1, 2 and 3 (each within the scatter of the next).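

In this assay the exchange to 4-carboxy-3-methylphenyl on an oxygen on a saturated carbon leaves the reading within the scatter, both against 3-carboxyphenyl (a number 1 percentage points higher from compound 2 to compound 3 (within the scatter)) and against 4-carboxy-2-methylphenyl (a number 1 percentage points higher from compound 1 to compound 3 (within the scatter)). The three carboxyphenyl groups at this place are thus not separated here, with or without the methyl group. No measurement at hand bears on why they read alike. Open, on these data alone, is whether a methyl ester or a primary amide in place of the carboxylic acid would keep this reading.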